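A few compounds are considered here, and "the series" means these few. Any claim that something is new, unique, unknown or untested is made for them only; others in the source may bear on it.

Compound 1, `CCCCCCCCCCC#Cc1cc2cn([C@@H]3O[C@H](CO)[C@@H](O)[C@@H]3O)c(=O)nc2o1`, gives 46000 nM.
Compound 2, `CCCCCCCCCCC#Cc1cc2cn([C@H]3C[C@H](O)[C@@H](CO)O3)c(=O)nc2o1`, gives 30000 nM.
Compound 3, `CCCCCCC#Cc1cc2cn([C@H]3C[C@H](O)[C@@H](CO)O3)c(=O)nc2o1`, gives only a limit of the assay, >= 97000 nM.

These three values come from a functional assay on HEL cells (Homo sapiens) for cytotoxicity; a lower number here means that less compound is tolerated, a higher number that more compound is tolerated. Compound 4, `CCCCCCC#Cc1cc2cn([C@@H]3O[C@H](CO)[C@@H](O)[C@@H]3O)c(=O)nc2o1`, has not yet been measured in this assay. Compound 4 differs from compound 3 by hydroxy in place of hydrogen on a saturated ring carbon. The same change separates compound 2 from compound 1, (hydroxy in place of hydrogen on a saturated ring carbon), where it made a 1.5-fold higher number from compound 2 to compound 1 (0.19 log units; within the scatter). The two places are the same word for word, so it is the same change on a different core. The cores of compound 3 and compound 4 differ from those of compound 2 and compound 1 by hydrogen in place of butyl on a saturated chain carbon, six bonds along the chain from a triple-bonded carbon, a change that made an at least 3.2-fold higher number from compound 2 to compound 3 (0.50 log units; beyond the scatter).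

Because compound 3 stands at the limit of >= 97000 nM in this assay, at which 1 of the 3 values shown sits, and because the matching change gave a 1.5-fold higher number from compound 2 to compound 1 (0.19 log units; within the scatter), compound 4 is expected to stay at or beyond that limit, so the expected step is a step that the limit leaves unreadable from compound 3 to compound 4. Compound 4 is therefore estimated at 120000 nM, with a range from 60000 nM to 250000 nM, and the reading may again be only a limit.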

Compound 4, minimum cytotoxic concentration: 133000 nM
The estimate for compound 4 lay 1.1-fold (0.04 log units) below the measured number; the measured number falls inside the stated range.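

Replacing butyl with hydrogen, six bonds along the chain from the triple-bonded carbon, also raises the number on the core carrying the extra hydroxy, with a 2.9-fold higher number from compound 1 to compound 4 (0.46 log units; beyond the scatter). Both steps therefore point the same way in this assay, but this does not show that the change has the same size on the two cores: the same change on two cores in this assay, an at least 3.2-fold higher number (0.50 log units; beyond the scatter) from compound 2 to compound 3 and a 2.9-fold higher number (0.46 log units; beyond the scatter) from compound 1 to compound 4; the limit leaves it open whether they differ. The step from hydrogen to hydroxy cannot be read on the shorter-chain core, so the data do not show whether that change carries over from the longer-chain core, where compound 3 marks a limit of the assay: the limit of >= 97000 nM in this assay, at which 1 of the 4 values shown sits.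

The compounds shown cover only two chain lengths and two cores, so it remains open whether the trend continues to a still longer chain. As far as these compounds go, it is also open how this assay would respond to an amine or a carboxylic acid at the end of the chain.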